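The source may hold more compounds than are shown below. What is called first, only, known or untested is meant among the compounds shown, and "the series" means these compounds.

Compound 1 `O=C(Nc1ccccc1)Nc1cccc(CNc2nccnc2Cl)c1` gives 16300 nM in a functional assay on MGC-803 cells (Homo sapiens) for antiproliferative activity, read by MTT assay, with a stated time of 48 h (a lower number here means a stronger inhibitor, a higher number a weaker inhibitor), the second highest of the three numbers recorded so far. Compound 2 `Cc1ccc(NC(=O)Nc2cccc(CNc3nccnc3Cl)c2)cc1Cl` gives 17500 nM, a change of a 1.1-fold higher number from compound 1 to compound 2 (0.03 log units; within the scatter). Compound 3 `O=C(Nc1cccc(CNc2nccnc2Cl)c1)Nc1ccc(Cl)cc1Br` gives 7480 nM, a change of a 2.2-fold lower number from compound 1 to compound 3 (0.34 log units; beyond the scatter). Compound 4 `CC(C)(C)c1ccc(NC(=O)Nc2cccc(CNc3nccnc3Cl)c2)cc1` is the next case: tert-butyl in place of hydrogen on an aromatic carbon. The measured steps all alter the aryl group on the amide-type nitrogen, so they bear on this change only loosely; adding ring substituents gave a 1.1-fold higher number from compound 1 to compound 2 (0.03 log units; within the scatter) in one case and a 2.2-fold lower number from compound 1 to compound 3 (0.34 log units; beyond the scatter) in the other. A step of at most modest size in either direction is therefore expected, most likely within the scatter. For compound 4 the expected value is 13000 nM, with a range of 5500 nM to 30000 nM. This estimate corresponds to an expected step of a 1.3-fold lower number from compound 1 to compound 4 (0.10 log units; within the scatter).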

Compound 4, half-maximal inhibitory concentration: 4820 nM
Compound 4: middle estimate off by 2.7-fold (0.43 log units), on the high side; the measured number lies below the stated range.
By their numbers in this assay, from the lowest: compounds 4 and 3 (each within the scatter of the next); then compounds 1 and 2 (each within the scatter of the next).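

In this assay, tert-butyl on this aromatic carbon, para to a large group, gives a 3.4-fold lower number from compound 1 to compound 4 (0.53 log units; beyond the scatter), so one added group with no other ring change can move the number beyond the scatter. The 3-chloro-4-methylphenyl change goes against any general gain from ring substitution, with a 1.1-fold higher number from compound 1 to compound 2 (0.03 log units; within the scatter). No measurement at hand accounts for the tert-butyl step. As far as these compounds go, whether the step depends on a branched carbon group remains open. An isopropyl group, an amine or a carboxylic acid at this place would test that.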